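From Ethoxy to Nitro on a Shared Core

The compounds below may be only part of what the source reports. "The series", "measured", "known", "first", "only" and "open" are said of these compounds alone.

Measured in a functional assay on HL-60 cells (Homo sapiens) for antiproliferative activity, read by MTT assay, with a stated time of 72 h; a higher number here means a weaker inhibitor, a lower number a stronger inhibitor:
Compound 1 `COc1cc(-n2ncnc2-c2ccc(C)cc2)cc(OC)c1OC`: 90 nM
Compound 2 `CCOc1cccc(-c2ncnn2-c2cc(OC)c(OC)c(OC)c2)c1`: > 10000 nM (a limit of the assay, not a number)

Compound 2 stands at the weak end of what this assay can report. Its reading of > 10000 nM is a limit. Compound 1 gives 90 nM, so the two values lie far apart.

Compound 3 `COc1cc(-n2ncnc2-c2cccc([N+](=O)[O-])c2)cc(OC)c1OC` has not yet been measured. Compared with compound 2, it carries nitro in place of ethoxy on an aromatic carbon, meta to a large group: nitro in place of ethoxy on an aromatic carbon.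

Among the measured compounds shown here, no measured step shows what such a swap does. A moderate gain in strength is expected, although compound 3 may well stay at the limit. The estimated step is an at least 3.3-fold lower number from compound 2 to compound 3 (0.52 log units; beyond the scatter). For compound 3 the estimated value is 3000 nM, with an expected range from 400 nM to 10000 nM.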

Compound 3, half-maximal inhibitory concentration: > 10000 nM
Compound 3: only a limit was reported; the forecaster's own chance of this, stated with the estimate: 40%; middle value at least 3.3-fold (0.52 log units) from the limit.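

The step from ethoxy to nitro cannot be read, because compound 2 and compound 3 both report only a limit of the assay, not a number: the limit of > 10000 nM in this assay, at which 2 of the 3 values shown sit.

Going by these compounds, how strongly either compound acts, and whether the swap changes that at all, stays open.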